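Swapping Fluoro for Methoxy beside a Benzoyl Anilide

The compounds below may be only part of what the source reports. "The series", "measured", "known", "first", "only" and "open" are said of these compounds alone.

Within the data shown here, compound 3 `CC(O)(C(=O)Nc1ccc(C(=O)c2ccccc2)cc1F)C(F)(F)F` gives 11000 nM in a functional assay (Cavia porcellus) with sulfonylurea receptors; K-ATP channels (Homo sapiens) as the target (on this read-out lower numbers stand for stronger inhibition and higher numbers for weaker inhibition), the highest of the three numbers measured so far; compound 2 `CC(O)(C(=O)Nc1ccc(S(=O)(=O)c2ccccc2Cl)cc1)C(F)(F)F` gives 2300 nM and compound 1 `COc1ccccc1S(=O)(=O)c1ccc(NC(=O)C(C)(O)C(F)(F)F)cc1` gives 1600 nM, both lower by margins beyond the scatter. Compound 4 `COc1cc(C(=O)c2ccccc2)ccc1NC(=O)C(C)(O)C(F)(F)F` differs from compound 3 by methoxy in place of fluoro on an aromatic carbon. Among the measured compounds shown here, only one measured step exists, a 1.4-fold higher number from compound 1 to compound 2 (0.16 log units; within the scatter), and it exchanges a different pair of groups, so it bears on this change only loosely: it shows that replacing one substituent on an aromatic carbon with another can leave this assay unchanged. For the measured compounds named here, no measured step compares methoxy with fluoro directly. The step expected in this assay is therefore a 1.2-fold lower number from compound 3 to compound 4 (0.09 log units; within the scatter), small and uncertain. Compound 4 is estimated at 9000 nM, with a range from 3000 nM to 30000 nM.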

Compound 4, half-maximal inhibitory concentration: 6100 nM
Estimate against measurement, compound 4: 1.5-fold (0.17 log units) above, and the stated range covers the measured number.
By their numbers in this assay, from the lowest: compounds 1 and 2 (each within the scatter of the next); then compounds 4 and 3 (each within the scatter of the next).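

In this assay, among these compounds, the first direct comparison of these two groups at this place, ortho to a large group, gives a 1.8-fold lower number from compound 3 to compound 4 (0.26 log units; within the scatter). Methoxy, with 2 heavy atoms and 1 hydrogen-bond acceptor, therefore cannot be told apart from fluoro, with 1 heavy atom and no acceptor, on this read-out. Nothing shown here accounts for this result.

Going by these compounds, whether an amine or a longer chain such as ethoxy at this place would also stay within the scatter remains open. Also open, on these data alone, is whether this exchange would give a similar step on the core of compound 1.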